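Chromenone series: trifluoromethyl for methyl on the pendant phenyl

The source may report more compounds than this note shows. Statements on the series, on what has been measured and on what is new or still open speak of the compounds shown alone.

Measured so far in a functional assay on KB cells (Homo sapiens) for antiproliferative activity, read by sulforhodamine B assay, with a stated time of 3 days; a lower number here means that less compound is needed, a higher number that more compound is needed for the effect:
compound 1 `CCC1=C(O)c2c(oc(-c3cccc(C)c3)cc2=O)C(CC)(CC)C1=O`: 49.7 uM
compound 2 `CCC1=C(O)c2c(oc(-c3cccc(C(F)(F)F)c3)cc2=O)C(CC)(CC)C1=O`: 35.7 uM
compound 3 `CCC1=C(O)c2c(oc(-c3ccccc3C)cc2=O)C(CC)(CC)C1=O`: 40.9 uM

Compound 2 differs from compound 1 by trifluoromethyl in place of methyl on an aromatic carbon, and that step gave a 1.4-fold lower number from compound 1 to compound 2 (0.14 log units; within the scatter). Compound 3 differs from compound 1 by 2-methylphenyl in place of 3-methylphenyl on an aromatic carbon, with a 1.2-fold lower number from compound 1 to compound 3 (0.08 log units; within the scatter). Compound 4 `CCC1=C(O)c2c(oc(-c3ccccc3C(F)(F)F)cc2=O)C(CC)(CC)C1=O` is not yet measured; it differs from compound 3 by trifluoromethyl in place of methyl on an aromatic carbon. This is the same kind of change as that from compound 1 to compound 2, not the same one: there the place was meta to a large group, here it is ortho to a large group. For the measured compounds named here, only one measured example of the change exists, so the expectation rests on it alone. Because a 1.4-fold lower number from compound 1 to compound 2 (0.14 log units; within the scatter) stayed within the scatter, a step of about a 1.3-fold lower number from compound 3 to compound 4 (0.12 log units; within the scatter) is expected in this assay . Compound 4 is estimated at 31 uM, between 15 uM and 62 uM.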

Compound 4, concentration for half-maximal effect: 45.6 uM
Compound 4: middle estimate off by 1.5-fold (0.17 log units), on the low side; the measured number falls inside the stated range.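

In this assay, trifluoromethyl in place of methyl gave a 1.1-fold higher number from compound 3 to compound 4 (0.05 log units; within the scatter), so in this second example the step again stays within the scatter. Set side by side, the two examples do not differ: the same change on two cores in this assay, a 1.4-fold lower number (0.14 log units; within the scatter) from compound 1 to compound 2 and a 1.1-fold higher number (0.05 log units; within the scatter) from compound 3 to compound 4, 1.6-fold (0.19 log units) apart, within the scatter of two such steps This is consistent with the change carrying from one core to the other in this assay, but with both steps inside the scatter, neither pair shows a real effect of the change, and two pairs cannot show how it would behave in a core where it has a larger effect.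

Open, from the compounds shown here alone, is how the pendant phenyl would respond to an amine or a carboxylic acid in place of methyl or trifluoromethyl. Also open, going by these compounds, is whether a longer chain in place of the ethyl groups on the shared core would move the number beyond the scatter.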